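Dithiocarbamate series: replacing the amine on the thiocarbonyl

The source may hold more compounds than are shown below. What is called first, only, known or untested is meant among the compounds shown, and "the series" means these compounds.

Compound 1 `COc1ccc(CN(C(=O)CSC(=S)N2CCN(C)CC2)c2cc(OC)c(OC)c(OC)c2)cc1` is the reference point. For the measured compounds named here, in a functional assay on KYSE-450 cells (Homo sapiens) for inhibition, read by CCK-8 assay, with a stated time of 48 h (a lower number here means a stronger inhibitor, a higher number a weaker inhibitor), compound 1 gives 1250 nM, the lowest number of the two measured so far. Compound 2 `COc1ccc(CN(C(=O)CSC(=S)N2CCOCC2)c2cc(OC)c(OC)c(OC)c2)cc1` differs from it only at the thiocarbonyl carbon, and in this assay compound 2 gives 7220 nM; the step of a 5.8-fold higher number from compound 1 to compound 2 (0.76 log units; beyond the scatter) shows that exchanging the group on that carbon moves the number upward by a modest, clearly resolved amount.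

Compound 3 `COc1ccc(CN(C(=O)CSC(=S)N2CCc3ccccc3C2)c2cc(OC)c(OC)c(OC)c2)cc1` has not yet been measured. Its difference from compound 1 is 1,2,3,4-tetrahydroisoquinolin-2-yl in place of 4-methylpiperazin-1-yl on a thiocarbonyl carbon. Going by the values given here, the change sits at the same place as the measured step, so that step is the only guide; both replacements remove the 4-methylpiperazin-1-yl group, and a weakening of comparable size is the natural expectation, though the new group is not the one tested. The expected step is a 3.2-fold higher number from compound 1 to compound 3 (0.51 log units; beyond the scatter). Compound 3 is estimated at 4000 nM, with a range from 1200 nM to 15000 nM.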

Compound 3, half-maximal inhibitory concentration: > 20000 nM
Compound 3 gave a limit, no number (the forecaster's own chance of this, stated with the estimate: 5%); middle value at least 5.0-fold (0.69 log units) from the limit.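

The group on the thiocarbonyl carbon has a wider effect in this assay than the morpholin-4-yl exchange alone showed: 1,2,3,4-tetrahydroisoquinolin-2-yl gives an at least 16-fold higher number from compound 1 to compound 3 (1.20 log units; beyond the scatter), and it also stands apart from morpholin-4-yl, with an at least 2.7-fold higher number from compound 2 to compound 3 (0.44 log units; beyond the scatter). Among these three compounds the order runs from 4-methylpiperazin-1-yl, with the lowest number, through morpholin-4-yl to 1,2,3,4-tetrahydroisoquinolin-2-yl, with the highest. The reading for compound 3 is a limit of the assay, not a number: the limit of > 20000 nM in this assay, at which 1 of the 3 values shown sits.

In compound 3 the aromatic ring enters as the second ring nitrogen leaves, and the compounds shown do not separate these two changes. On these data alone, whether the number depends on that nitrogen, on its methyl group or on the aromatic ring remains open, and a piperidin-1-yl or 4-ethylpiperazin-1-yl group would bear on this.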